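A Methyl Replaces Hydrogen on a Weak Inhibitor

This account rests on a few compounds, and the source may have more. Where it says the series, first, only, none or still open, it means among the compounds named here.

Within the data shown here, compound 2 `C/C(=N/NC(=O)c1ccncc1)c1ccc(N/C(S)=N/c2ccccc2)cc1` gives 160000 nM in a functional assay on Vero cells (Chlorocebus sabaeus) for inhibition, read by MTT assay (on this read-out higher numbers stand for weaker inhibition and lower numbers for stronger inhibition), the only actual number reported among the two measured compounds. Compound 1 `C/C(=N/NC(=O)c1ccncc1)c1ccc(N/C(S)=N/c2ccc(F)cc2)cc1` gives > 153000 nM in this assay, which is a limit and not a number. Among the measured compounds shown here, the step that the limit leaves unreadable from compound 1 to compound 2 cannot be read because of the limit of > 153000 nM in this assay, at which 1 of the 2 values shown sits, so the single measured step says nothing about its size. Compound 3 `C/C(=N/NC(=O)c1ccncc1)c1ccc(N/C(S)=N/c2ccc(C)cc2)cc1` differs from compound 2 by methyl in place of hydrogen on an aromatic carbon, a methyl in place of hydrogen on an aromatic carbon, para to a large group. For the measured compounds named here, no measured step bears on this change, and the only comparison available is unreadable. No shift beyond the usual scatter is therefore expected in this assay for compound 3, and the result may again come back as a limit. Compound 3 is estimated at 160000 nM, with a range from 60000 nM to 400000 nM. The estimated step of no change at the digits printed from compound 2 to compound 3 (within the scatter) lies within the scatter.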

Compound 3, half-maximal inhibitory concentration: 155000 nM
For compound 3 the middle estimate is 1.0-fold (0.01 log units) above the measured one, and the stated range covers the measured number.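

The replacement of phenyl by 4-methylphenyl gives a 1.0-fold lower number from compound 2 to compound 3 (0.01 log units; within the scatter) in this assay. Among these compounds, this is the first readable step at this position, and it shows that a methyl on this aromatic carbon, para to a large group, leaves the read-out where hydrogen had it. The steps from compound 1 to compound 2 and from compound 1 to compound 3 cannot be read, so fluoro cannot be set against hydrogen or methyl here, because the value of compound 1 is a limit and not a number: the limit of > 153000 nM in this assay, at which 1 of the 3 values shown sits.

From the compounds shown here alone, it stays open whether an amine, a carboxylic acid or a longer chain in place of the methyl would move the number beyond the scatter. Going by these compounds, it also stays open whether any replacement elsewhere in the shared core would do so.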